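A few compounds are considered here, and "the series" means these few. Any claim that something is new, unique, unknown or untested is made for them only; others in the source may bear on it.

Measured compounds in an assay on cells for inhibition of Rho-associated protein kinase 2 (Homo sapiens), read by radiometric assay and 33P incorporation, in the presence of a further agent that is not named here; on this read-out higher numbers stand for weaker inhibition and lower numbers for stronger inhibition:
compound 1 `NCc1ccc(C(=O)Nc2ccncc2F)cc1-c1cccc(NC(=O)c2cccc(C(=O)O)c2)c1` gives < 1 nM, a limit of the assay and not a number.
compound 2 `CCCOC(=O)c1cccc(C(=O)Nc2cccc(-c3cc(C(=O)Nc4ccncc4F)ccc3CN)c2)c1` gives 1.8 nM.
compound 3 `CCCCOC(=O)c1cccc(NC(=O)c2cccc(-c3cc(C(=O)Nc4ccncc4F)ccc3CN)c2)c1` gives 27 nM.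

Of the two numbers that were reported outright, compound 2 holds the lower one, and compound 3 sits a good deal higher, beyond the scatter. Compound 1 is recorded only as a limit, the line at which one of the three values rests (the limit of < 1 nM in this assay, at which 1 of the 3 values shown sits).

Compound 4 `NCc1ccc(C(=O)Nc2ccncc2F)cc1-c1cccc(NC(=O)c2cc(C(=O)O)ccc2F)c1` has not yet been measured. Against compound 2 it shows the change (5-carboxy-2-fluorophenyl in place of 3-(propoxycarbonyl)phenyl on a carbonyl carbon).

One measured step speaks to this change. From compound 1 to compound 2 the propyl ester was put in place of the free acid on the oxygen beside the carbonyl, and the number rose an at least 1.8-fold higher number from compound 1 to compound 2 (0.25 log units; that floor lies within the scatter). The change from compound 2 to compound 4 removes that propyl again and returns a free carboxylic acid, now on a 5-carboxy-2-fluorophenyl group. Within the data shown here, the added fluorine has no measured counterpart among the three compounds, so its effect is not known here.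

On this basis compound 4 is expected to come out lower than compound 2, the step being a 2.3-fold lower number from compound 2 to compound 4 (0.35 log units; beyond the scatter), with a fair chance that the assay returns only a limit. The estimate for compound 4 in this assay is 0.8 nM, within a range of 0.3 nM to 2.5 nM.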

Compound 4, half-maximal inhibitory concentration: < 1 nM
Compound 4: no number, only a limit (the forecaster's own chance of this, stated with the estimate: 50%); the middle value lies beyond the limit too.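

In this assay, the place on a carbonyl carbon whose other neighbour is an amide-type nitrogen now carries 5-carboxy-2-fluorophenyl in place of 3-(propoxycarbonyl)phenyl, and the result is an at least 1.8-fold lower number from compound 2 to compound 4 (0.25 log units; that floor lies within the scatter). Compound 4 gives < 1 nM, which is a limit of the assay and not a number. The earlier compounds showed a free carboxylic acid at the limit only without a fluoro group on that ring, whereas compound 4 shows that the acid can carry fluoro in place of hydrogen on an aromatic carbon and the read-out still does not leave the limit, so two compounds with a free acid now rest there: the limit of < 1 nM in this assay, at which 2 of the 4 values shown sit.

On these data alone, the step between compound 1 and compound 4 cannot be read, as both stand at the limit, so whether the fluoro group shifts the true number in either direction stays open. Also open, as far as these compounds go, is how this fluorinated ring behaves when the carboxylic acid gives way to a propyl ester, a primary amide or a tetrazole.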